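Removing One Chloro From a Dichloro Core

The compounds below may be only part of what the source reports. "The series", "measured", "known", "first", "only" and "open" are said of these compounds alone.

Compound 2 `ClCc1ccccc1Cn1cnc2c(Cl)nc(Cl)nc21` was measured in a functional assay on NCI-H322M cells (Homo sapiens) for cytotoxicity, read by sulforhodamine B assay, with a stated time of 48 h (a higher number here means a weaker inhibitor of growth, a lower number a stronger inhibitor of growth), and gives 1730 nM. Compound 1 `ClCc1ccc(Cn2cnc3c(Cl)ncnc32)cc1` gives 1820 nM in this assay. The two numbers lie within the scatter of each other, so neither compound stands apart. Compound 3 `ClCc1ccccc1Cn1cnc2c(Cl)ncnc21` has not yet been measured. It differs from compound 2 by hydrogen in place of chloro on an aromatic carbon. Among the measured compounds shown here, no measured pair shows this change alone, so the expected step of a 1.0-fold higher number from compound 2 to compound 3 (0.00 log units; within the scatter) is none beyond the scatter. Compound 3 is therefore estimated at 1750 nM, with a range from 800 nM to 3800 nM.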

Compound 3, concentration for 50% growth inhibition: 3980 nM
Compound 3: the middle estimate sits 2.3-fold (0.36 log units) below what was measured; the whole stated range lies below it.
By their numbers in this assay, from the lowest: compounds 2 and 1 (each within the scatter of the next); then compound 3.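

On the aromatic carbon between two ring nitrogen atoms, the group present does matter: in this assay, hydrogen in place of chloro gives a 2.3-fold higher number from compound 2 to compound 3 (0.36 log units; beyond the scatter), a modest loss of growth inhibition. Among the compounds shown here, this single change is the first measured here to separate two compounds beyond the scatter. Nothing measured here accounts for the step. As far as these compounds go, whether an amine or a methoxy group on this carbon would restore or improve growth inhibition remains open. So does whether the chloro contributes equally when the chloromethyl group sits elsewhere on its ring.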